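The source may hold more compounds than are shown below. What is called first, only, known or untested is meant among the compounds shown, and "the series" means these compounds.

In a functional assay on BT-549 cells (Homo sapiens) for inhibition, read by sulforhodamine B assay, with a stated time of 48 h (on this read-out lower numbers stand for higher toxicity in this test and higher numbers for lower toxicity in this test), compound 1 `O=C(Nc1cccc(-n2cc(-c3ccncc3)c(-c3ccc(Cl)c(O)c3)n2)c1)Nc1cccc(C(F)(F)F)c1` gives > 32500 nM, which is a limit and not a number. Compound 2 `O=C(Nc1cccc(-n2cc(-c3ccncc3)c(-c3ccc(Cl)c(O)c3)n2)c1)Nc1ccc(Cl)c(Cl)c1` gives > 32500 nM, which is also a limit. Both compounds thus sit at the same point, (the limit of > 32500 nM in this assay, at which 2 of the 2 values shown sit), so nothing shows where compound 1 stands beyond that limit. For the measured compounds named here, the one measured step, a step that the two limits leave unreadable from compound 1 to compound 2, cannot be sized, and it offers no guide to how much a change on this aromatic ring matters. Compound 3 `O=C(Nc1cccc(-n2cc(-c3ccncc3)c(-c3ccc(Cl)c(O)c3)n2)c1)Nc1cc(C(F)(F)F)cc(C(F)(F)F)c1` keeps the shared core of compound 1 and differs from it on that ring: trifluoromethyl in place of hydrogen on an aromatic carbon. The new trifluoromethyl sits meta to the trifluoromethyl group already present. With no readable step to draw on, no step beyond the scatter is expected in this assay, and no direction can be argued. The expectation rests on compound 1 at its limit of > 32500 nM. The expected size is a step that the limit leaves unreadable from compound 1 to compound 3. For compound 3 the estimated value is 40000 nM, with an expected range from 15000 nM to 100000 nM, and a further limit is the likeliest report.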

Compound 3, concentration lethal to 50% of the cells: 4110 nM
Estimate against measurement, compound 3: 9.7-fold (0.99 log units) above; the whole stated range lies above it.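

The added trifluoromethyl, meta to the trifluoromethyl group already present, brings an at least 7.9-fold lower number from compound 1 to compound 3 (0.89 log units; beyond the scatter) in this assay, so a change at this place on the ring can move the read-out beyond the scatter. The earlier pair could not show this, as neither of its steps' ends was a number, and its one step cannot be read; compound 3 is the first of the series shown to give a measured value, and on this read-out its lower number stands for higher toxicity in the test. The true size of the step stays open on one side, and the other two compounds remain at a limit: the limit of > 32500 nM in this assay, at which 2 of the 3 values shown sit.

The compounds shown leave open whether the step belongs to trifluoromethyl itself or would also follow from another group at this place, such as a chlorine, a methoxy group, an amine or a carboxylic acid. They also leave open whether the same group would give a similar step without the first trifluoromethyl on the ring, or on the core of compound 1 with the chloro and hydroxy groups changed.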